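The compounds below may be only part of what the source reports. "The series", "measured", "known", "first", "only" and "open" are said of these compounds alone.

In a functional assay on L1210 cells (Mus musculus) for inhibition (on this read-out lower numbers stand for stronger inhibition and higher numbers for weaker inhibition), the measured compounds stand as follows.
Compound 1 `NC1=NC(N)c2c(ncn2C=C=CCO)N1` gives 60000 nM.
Compound 2 `Nc1nc(O)c2ncn(C=C=CCO)c2n1` gives only a limit of the assay, > 350000 nM.
Compound 3 `NC1=NC(N)c2c(ncn2CC#CCO)N1` gives 200000 nM.

Compound 3 differs from compound 1 in one place, (4-hydroxybut-2-yn-1-yl in place of 4-hydroxybuta-1,2-dien-1-yl on an aromatic nitrogen), and the result was a 3.3-fold higher number from compound 1 to compound 3 (0.52 log units; beyond the scatter). Compound 4 `Nc1nc(O)c2ncn(CC#CCO)c2n1` is not yet measured and differs from compound 2 by the same kind of change, (4-hydroxybut-2-yn-1-yl in place of 4-hydroxybuta-1,2-dien-1-yl on an aromatic nitrogen). The surroundings are not described in the same words: for compound 1 the ring nitrogen is next to the ring atom that bears a fused ring, with two ring bonds from that atom, which the description for compound 2 does not mention. How the core of compound 2 differs from that of compound 1 is not broken down here. Compound 2 sits at the limit of > 350000 nM in this assay, at which 1 of the 3 values shown sits. From compound 2 to compound 4 the step expected is a step that the limit leaves unreadable from compound 2 to compound 4 in this assay, resting on a 3.3-fold higher number from compound 1 to compound 3 (0.52 log units; beyond the scatter), and the result is expected to be again only a limit. Compound 4 is thus estimated at about 1000000 nM, between 350000 nM and 3000000 nM.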

Compound 4, half-maximal inhibitory concentration: 210000 nM
Compound 4: middle estimate off by 4.8-fold (0.68 log units), on the high side; the measured number lies below the stated range.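

On the core of compound 2, putting 4-hydroxybut-2-yn-1-yl in place of 4-hydroxybuta-1,2-dien-1-yl in this assay gives an at least 1.6-fold lower number from compound 2 to compound 4 (0.22 log units; that floor lies within the scatter). The step on the core of compound 1 therefore does not carry over as a fixed shift to this core: the same change on two cores in this assay, a 3.3-fold higher number (0.52 log units; beyond the scatter) from compound 1 to compound 3 and an at least 1.6-fold lower number (0.22 log units; that floor lies within the scatter) from compound 2 to compound 4, at least 5.5-fold (0.74 log units) apart, beyond the scatter of two such steps. On these data alone, compound 2 gives only a limit of the assay, > 350000 nM, so the exact size of its step stays unknown, and a single pair on each core does not show what sets the two cores apart.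

As far as these compounds go, it remains open whether a longer chain, or an amine or carboxylic acid in place of the hydroxy group, would shift the number alike on both cores.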